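Trifluoromethyl Added to an Amidine Anilide

A few compounds are considered here, and "the series" means these few. Any claim that something is new, unique, unknown or untested is made for them only; others in the source may bear on it.

In a functional assay on HT-1080 cells (Homo sapiens) for cytotoxicity, read by MTT assay, with a stated time of 72 h (on this read-out higher numbers stand for weaker inhibition and lower numbers for stronger inhibition), compound 3 `COc1ccc(Cn2ncc3cc(C(=N)Nc4ccccc4)ncc32)cc1` gives 25700 nM, which is the higher of the two numbers in hand. Compound 1 `CN1CCN(c2ccc(NC(=N)c3cc4cnn(C)c4cn3)cc2)CC1` gives 24000 nM in this assay, and the two values sit within the scatter of each other, so they are best read as equivalent. Compound 2 `N=C(Nc1ccccc1)c1cc2cn[nH]c2cn1` gives "not determined" (no result reported) in this assay, so no number is in hand for it.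

Compound 4 `COc1ccc(Cn2ncc3cc(C(=N)Nc4cccc(C(F)(F)F)c4)ncc32)cc1` carries trifluoromethyl in place of hydrogen on an aromatic carbon. For the measured compounds named here, no measured pair shows this change, so the step from compound 3 to compound 4 can only be anticipated. A step of modest size is expected, toward stronger inhibition, probably beyond the scatter but not by much, so that a 2.1-fold lower number from compound 3 to compound 4 (0.33 log units; beyond the scatter) is estimated. Compound 4 is therefore expected to give 12000 nM in this assay, within a range from 4000 nM to 36000 nM.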

Compound 4, half-maximal inhibitory concentration: 24900 nM
Compound 4: the middle estimate sits 2.1-fold (0.32 log units) below what was measured; low and high end bracket the measured number.
By their numbers in this assay, from the lowest: compounds 1, 4 and 3 (each within the scatter of the next).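

In this assay, trifluoromethyl in place of hydrogen on this aromatic carbon, meta to a large group, gives a 1.0-fold lower number from compound 3 to compound 4 (0.01 log units; within the scatter), so phenyl and 3-(trifluoromethyl)phenyl read as equivalent here. At this position, the four added heavy atoms leave the read-out unmoved. No measurement in hand says why the step is this small.

Going by these compounds, whether an amine or a carboxylic acid on this same carbon would give a different number stays open. So does whether trifluoromethyl would read alike on the core of compound 1.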